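Chain homologation on the acrylamide in two sulfide/sulfone cores

The source may report more compounds than this note shows. Statements on the series, on what has been measured and on what is new or still open speak of the compounds shown alone.

Measured compounds:
- compound 1 `CC/C=C\C(=O)Nc1cc(Nc2nc3c(c(-c4cn(C)c5ccccc45)n2)CSCC3)c(OC)cc1N(C)CCN(C)C`: 236 nM
- compound 2 `COc1cc(N(C)CCN(C)C)c(NC(=O)/C=C\C(C)C)cc1Nc1nc2c(c(-c3cn(C)c4ccccc34)n1)CSCC2`: 788 nM
- compound 3 `C/C=C\C(=O)Nc1cc(Nc2nc3c(c(-c4cn(C)c5ccc(F)cc45)n2)CS(=O)(=O)CC3)c(OC)cc1N(C)CCN(C)C`: 3990 nM

In a functional assay on A549 cells (Homo sapiens) for inhibition, read by MTT assay, with a stated time of 72 h (on this read-out higher numbers stand for weaker inhibition and lower numbers for stronger inhibition), compound 1 gives 236 nM and compound 2 gives 788 nM. The change between them is methyl in place of hydrogen on a saturated chain carbon bound to a double-bonded chain carbon and a saturated chain carbon, and it makes a 3.3-fold higher number from compound 1 to compound 2 (0.52 log units; beyond the scatter). Compound 3 has a different core, and the difference between the two cores is not broken down here; in this assay compound 3 gives 3990 nM, the highest of the three numbers.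

Compound 4 `CC/C=C\C(=O)Nc1cc(Nc2nc3c(c(-c4cn(C)c5ccc(F)cc45)n2)CS(=O)(=O)CC3)c(OC)cc1N(C)CCN(C)C` is not yet measured. It differs from compound 3 by methyl in place of hydrogen on a saturated chain carbon bound to a double-bonded chain carbon. Going by the values given here, this is the same kind of change as the one from compound 1 to compound 2, but not the same: there the carbon also bore a saturated chain carbon, here it is bound only to a double-bonded chain carbon. The earlier step rests on one pair in one core and the surroundings of the place differ, so it gives only a rough guide. A step of similar direction and somewhat smaller size is expected, a 1.6-fold higher number from compound 3 to compound 4 (0.21 log units; within the scatter), resting on the weakening seen as a 3.3-fold higher number from compound 1 to compound 2 (0.52 log units; beyond the scatter). Compound 4 is estimated at 6500 nM, within 2200 nM to 20000 nM.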

Compound 4, half-maximal inhibitory concentration: 5830 nM
Estimate against measurement, compound 4: 1.1-fold (0.05 log units) above, and the stated range covers the measured number.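

In this assay, methyl in place of hydrogen on a saturated chain carbon bound to a double-bonded chain carbon, taking prop-1-en-1-yl to but-1-en-1-yl on the core of compound 3, gives a 1.5-fold higher number from compound 3 to compound 4 (0.16 log units; within the scatter), so this step alone does not separate the two compounds. Set beside the earlier step, it shows no difference that can be told from scatter: the same change on two cores in this assay, a 3.3-fold higher number (0.52 log units; beyond the scatter) from compound 1 to compound 2 and a 1.5-fold higher number (0.16 log units; within the scatter) from compound 3 to compound 4, 2.3-fold (0.36 log units) apart, within the scatter of two such steps

The two steps are therefore compatible with one effect carried across both cores, but with a single pair on each core and a carbon whose surroundings differ between the pairs, this does not establish that the change transfers, and the step beyond the scatter has so far been seen on the core of compound 1 only.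

The compounds shown leave open whether a longer chain or a dimethylamino group at this carbon would follow the same course on both cores. No pair shown differs in the core alone, so the contribution of the core itself remains unresolved.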